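Amide substituent change from benzyl to aryl in the shared core

The source may hold more compounds than are shown below. What is called first, only, known or untested is meant among the compounds shown, and "the series" means these compounds.

Among the compounds with values here, of the two numbers so far in a functional assay on Huh-7 cells (Homo sapiens) for inhibition, read by MTT assay, with a stated time of 48 h (a lower number here means a stronger inhibitor, a higher number a weaker inhibitor), compound 2 `COc1ccc(CNC(=O)/C=C/c2coc3cc(OC)ccc3c2=O)cc1` sits at 7570 nM and compound 1 `COc1ccc2c(=O)c(/C=C/C(=O)NCc3ccccc3F)coc2c1` at 8450 nM; the step of a 1.1-fold lower number from compound 1 to compound 2 (0.05 log units; within the scatter) is within the scatter, so neither compound is separated from the other. Compound 3 `COc1ccc2c(=O)c(/C=C/C(=O)Nc3ccc(Cl)cc3)coc2c1` has not been measured. It differs from compound 2 by 4-chlorophenyl in place of 4-methoxybenzyl on an amide-type nitrogen. Within the data shown here, the only measured step, the swap of 4-methoxyphenyl for 2-fluorophenyl on the saturated chain carbon bound to the amide-type nitrogen, did not move the number beyond the scatter. Among the measured compounds shown here, no measured step tests an aryl group bound to the amide-type nitrogen itself, so this change is untested here. Nothing in the data points to a shift in this assay, and the expected step of a 1.1-fold higher number from compound 2 to compound 3 (0.02 log units; within the scatter) is none beyond the scatter, with a wide range. Compound 3 is estimated at 8000 nM, between 3000 nM and 22000 nM.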

Compound 3, half-maximal inhibitory concentration: 37100 nM
Estimate against measurement, compound 3: 4.6-fold (0.67 log units) below; the measured number lies above the stated range.
By their numbers in this assay, from the lowest: compounds 2 and 1 (each within the scatter of the next); then compound 3.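

In this assay, within the data shown here, the group on the amide-type nitrogen is the first place where a change separates compounds: 4-chlorophenyl gives a 4.9-fold higher number from compound 2 to compound 3 (0.69 log units; beyond the scatter) against 4-methoxybenzyl, and a 4.4-fold higher number from compound 1 to compound 3 (0.64 log units; beyond the scatter) against 2-fluorobenzyl, both beyond the scatter. The two benzyl compounds stand within the scatter of each other, so the step appears from either one, whereas the ring change between them alone did not separate them. Nothing available explains this step.

The change removes the saturated chain carbon and alters the ring substituent together, so the compounds shown cannot assign the step to either part. A 4-chlorobenzyl group or a 4-methoxyphenyl group on the same nitrogen would separate the two, and a 2-phenylethyl group would extend the chain question in the other direction.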